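Methoxy to (carboxymethyl)amino on the quinone ring

This account rests on a few compounds, and the source may have more. Where it says the series, first, only, none or still open, it means among the compounds named here.

In an ADME assay on L1210 cells (Mus musculus) for cytotoxicity, with a stated time of 48 h (a lower number here means a stronger inhibitor, a higher number a weaker inhibitor), compound 2 `COC1=CC(=O)C(O)=C(C/C=C(\C)CC[C@@]2(C)CCC=C(C)[C@H]2C)C1=O` gives 2 ug/mL. Compound 1 `C=C1[C@H](C)CCC[C@]1(C)CC/C(C)=C/CC1=C(O)C(=O)C=C(N[C@@H](C(=O)O)C(C)C)C1=O` gives 3.4 ug/mL, and compound 3 `C=C1[C@H](C)CCC[C@]1(C)CC/C(C)=C/CC1=C(O)C(=O)C=C(N[C@H](C(=O)O)C(C)C)C1=O` gives 4.4 ug/mL; compound 2 thus sits within the scatter of compound 1 and below compound 3 by more than the scatter. Among the measured compounds shown here, the only measured step, a 1.3-fold higher number from compound 1 to compound 3 (0.11 log units; within the scatter), is a change of configuration alone, as stated by the fact that compounds 1 and 3 differ only in the configuration as drawn, and it does not touch the substituent question raised by compound 4 `CC1=CCC[C@](C)(CC/C(C)=C/CC2=C(O)C(=O)C=C(NCC(=O)O)C2=O)[C@@H]1C`. Compound 4 differs from compound 2 by (carboxymethyl)amino in place of methoxy on a double-bonded ring carbon. For the measured compounds named here, no step with a comparable exchange has been measured; what can be said is that compounds 1 and 3, which carry an amino-acid substituent on their core, give numbers in the same range as the methoxy compound 2, so a large move in either direction is not anticipated. Compound 4 is therefore estimated at 3.5 ug/mL, between 1.5 ug/mL and 8 ug/mL, which expects a step of a 1.8-fold higher number from compound 2 to compound 4 (0.24 log units; within the scatter), roughly within the scatter.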

Compound 4, half-maximal inhibitory concentration: 3.5 ug/mL
Compound 4: middle estimate and measured number agree at the digits printed; measured number inside the range.
By their numbers in this assay, from the lowest: compounds 2, 1, 4 and 3 (each within the scatter of the next, the first and the last beyond it).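

In this assay, among the compounds shown here, the exchange of methoxy for (carboxymethyl)amino on a double-bonded ring carbon gives a 1.8-fold higher number from compound 2 to compound 4 (0.24 log units; within the scatter) and is the first direct reading of a substituent change at this place. The earlier step covered configuration alone, whereas this one shows that a group with more heavy atoms and added hydrogen-bond donors can stand here without a move beyond the scatter. The reading holds for this one pair on this one core and sets no trend for the position.

Still open, as far as these compounds go, is whether a simple amine, a carboxylic acid set directly on the ring carbon, or a longer chain ending in a carboxylic acid would read the same at this place. No measured property at hand bears on the cause of this reading.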